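A few compounds are considered here, and "the series" means these few. Any claim that something is new, unique, unknown or untested is made for them only; others in the source may bear on it.

In a functional assay on a cell-free system (Platelet, plasma, Homo sapiens) for inhibition (on this read-out lower numbers stand for stronger inhibition and higher numbers for weaker inhibition), compound 1 `O=C(O)COC1CCN(CCN(C(=O)c2ccc(F)cc2)c2ccc(Cl)cc2)CC1` gives 2000 nM and compound 2 `COc1ccc(C(=O)N(CCN2CCC(OCC(=O)O)CC2)c2ccc(Cl)cc2)cc1` gives 3100 nM. Compound 2 therefore stands within the scatter of compound 1, as a 1.6-fold higher number from compound 1 to compound 2 (0.19 log units; within the scatter) shows, with methoxy in place of fluoro on an aromatic carbon. For compound 3 `O=C(O)COC1CCN(CCN(C(=O)c2ccc(-c3ccccc3)cc2)c2ccc(Cl)cc2)CC1`, this assay gives only a limit, > 10000 nM.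

The next compound, compound 4 `Cc1cccc(C(=O)N(CCN2CCC(OCC(=O)O)CC2)c2ccc(Cl)cc2)c1`, differs from compound 2 in one place: 3-methylphenyl in place of 4-methoxyphenyl on a carbonyl carbon. This puts 3-methylphenyl in place of 4-methoxyphenyl on a carbonyl carbon. Among the compounds with values here, no measured compound carries this 3-methylphenyl group, so the measured steps bear on the change only indirectly. The closest guide is a 1.6-fold higher number from compound 1 to compound 2 (0.19 log units; within the scatter), which stays within the scatter. The larger changes are an at least 5.0-fold higher number from compound 1 to compound 3 (0.69 log units; beyond the scatter) and an at least 3.2-fold higher number from compound 2 to compound 3 (0.50 log units; beyond the scatter), both beyond the scatter and both resting on (the limit of > 10000 nM in this assay, at which 1 of the 3 values shown sits). They involve phenyl as the incoming group, a change that compound 4 does not share. The expectation therefore follows the step between compound 1 and compound 2 and not those to compound 3. The expected change is small, with a 1.2-fold lower number from compound 2 to compound 4 (0.08 log units; within the scatter) estimated to stay within the scatter and no direction favoured. For compound 4, the estimated value is 2600 nM, with an expected range from 1000 nM to 7000 nM.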

Compound 4, half-maximal inhibitory concentration: 310 nM
Compound 4: middle estimate off by 8.4-fold (0.92 log units), on the high side, outside the stated range (below it).
By their numbers in this assay, from the lowest: compound 4; then compounds 1 and 2 (each within the scatter of the next). At a limit, above all of these: compound 3.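

In this assay, the group on the carbonyl carbon proves able to move the read-out towards stronger inhibition, with a 10-fold lower number from compound 2 to compound 4 (1.00 log units; beyond the scatter) and a 6.5-fold lower number from compound 1 to compound 4 (0.81 log units; beyond the scatter), both beyond the scatter. Within the data shown here, until now, the only change beyond the scatter at this place had gone towards weaker inhibition, with compound 3, while compound 1 and compound 2 lay within the scatter of each other, so 3-methylphenyl is the first group here to separate clearly from 4-fluorophenyl and 4-methoxyphenyl in the favourable direction. The compounds shown hold no measurement that would explain this gain.

Going by these compounds, what remains open is whether the gain belongs to the methyl group itself or to where it sits, since the step from 4-methoxyphenyl to 3-methylphenyl changes both at once. On these data alone, it is also open whether an ethyl or a trifluoromethyl group in place of that methyl would keep, extend or lose the gain in this assay.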